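The source may report more compounds than this note shows. Statements on the series, on what has been measured and on what is new or still open speak of the compounds shown alone.

In an assay on membranes from HEK293 cells for displacement of a labelled ligand from adenosine receptor A2b (Homo sapiens), read by scintillation counting, with a stated time of 30 min, tested at 1 uM (on this read-out lower numbers stand for less inhibition and higher numbers for more inhibition at the one concentration tested (going by the name of the read-out)), compound 2 `CC1=C(C(=O)OCC(C)C)C(c2ccsc2)NC(=O)N1C` gives 1%, the lower of the two numbers in hand. Compound 1 `CC1=C(C(=O)OC(C)(C)C)C(c2cccs2)NC(=O)N1C` gives 24% in this assay, a value beyond the scatter above compound 2, though the two compounds differ in more than one place, so nothing isolates either change. Compound 3 `CC1=C(C(=O)OC(C)(C)C)C(c2ccsc2)NC(=O)N1C` is not yet measured; it carries tert-butyl in place of isobutyl on an oxygen next to a carbonyl group. Within the data shown here, with no measured step for this change alone, only a modest rise is expected, and the expected step in this assay is a number 9 percentage points higher from compound 2 to compound 3 (within the scatter), which may still fall within the scatter. Compound 3 is accordingly expected to give 10%, with a range from 0% to 28%.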

Compound 3, a percentage reported as inhibition, at one concentration (the size of the read-out at that concentration, not a potency): 35%
Compound 3: the middle estimate sits 25 percentage points below what was measured; the whole stated range lies below it.
By their numbers in this assay, from the lowest: compound 2; then compound 1; then compound 3.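

Tert-butyl in place of isobutyl on an oxygen next to a carbonyl group now stands as a single change in this assay, and it gives a number 34 percentage points higher from compound 2 to compound 3 (beyond the scatter) with thiophen-3-yl held constant. With tert-butyl held constant, thiophen-3-yl in place of thiophen-2-yl on a saturated ring carbon gives a number 11 percentage points higher from compound 1 to compound 3 (beyond the scatter), so both places bear on this read-out. No evidence on the reason for either step is in hand.

Going by these compounds, whether the tert-butyl step carries over to the thiophen-2-yl compounds stays open. So does the reading for a longer chain or a cyclopropyl group on that oxygen, or for a phenyl ring in place of the thiophen-3-yl group.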